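Swapping the anilide ring of compound 1 for a fluoropyridine

This account rests on a few compounds, and the source may have more. Where it says the series, first, only, none or still open, it means among the compounds named here.

Compound 1 has the structure `CC(C)n1ncc2c(C(=O)Nc3ccc(F)cc3)cc(-c3cccs3)nc21`. In an ADME assay on LLC-MK2 cells (Macaca mulatta) for cytotoxicity, read by spectrophotometry and crystal violet staining, with a stated time of 4 days (on this read-out lower numbers stand for higher toxicity in this test and higher numbers for lower toxicity in this test), compound 1 gives > 200000 nM, which is a limit of the test rather than a number. Compound 2, `CC(C)n1ncc2c(C(=O)Nc3ccc(F)cc3)cc(-c3ccsc3)nc21`, carries thiophen-3-yl in place of thiophen-2-yl on an aromatic carbon. In this assay compound 2 gives > 200000 nM, again a limit. The step that the two limits leave unreadable from compound 1 to compound 2 therefore cannot be read. Compound 3, `CC(C)n1ncc2c(C(=O)Nc3ccccc3F)cc(-c3ccncc3)nc21`, differs from compound 1 in two places at once. In this assay compound 3 gives 45000 nM. Two of the three values sit at the limit of > 200000 nM in this assay, at which 2 of the 3 values shown sit.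

The unmeasured compound 4 has the structure `CC(C)n1ncc2c(C(=O)Nc3ccc(F)cn3)cc(-c3cccs3)nc21`. Its change from compound 1 is 5-fluoropyridin-2-yl in place of 4-fluorophenyl on an amide-type nitrogen. No measured step touches the group on the amide-type nitrogen, so nothing shown bears directly on this change. Given that compound 1 sits at the limit of > 200000 nM in this assay, at which 2 of the 3 values shown sit, compound 4 is expected to remain at or near that limit, with an estimated step of a number no higher from compound 1 to compound 4 (the limit leaves the size open) that is not expected to exceed the scatter. Compound 4 is estimated at 200000 nM, within 60000 nM to 600000 nM.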

Compound 4, half-maximal cytotoxic concentration: > 200000 nM
Compound 4 was reported as a limit (the forecaster's own chance of this, stated with the estimate: 70%); the middle value lies on the limit itself.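

Compound 4, like compound 1, is reported in this assay only as a limit and not as a number, so no step between them can be read: the limit of > 200000 nM in this assay, at which 3 of the 4 values shown sit.

The compounds shown leave open whether 5-fluoropyridin-2-yl in place of 4-fluorophenyl changes the half-maximal cytotoxic concentration at all, and by how much.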